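Dropping Bromo from the Amine Side: Effect on Cell Tolerance

This account rests on a few compounds, and the source may have more. Where it says the series, first, only, none or still open, it means among the compounds named here.

Compound 1 `FC(F)(F)c1ccc(NCc2cn(-c3ccccc3)nc2-c2ccc(Br)cc2)cc1` and compound 3 `FC(F)(F)c1ccc(NCc2cn(-c3ccccc3)nc2-c2ccccc2)cc1` share a core and differ at a single point, (hydrogen in place of bromo on an aromatic carbon). In an ADME assay on MDBK cells (Bos taurus) for cytotoxicity, read by MTT assay, with a stated time of 72 h (a higher number here means that more compound is tolerated, a lower number that less compound is tolerated), compound 1 gives 46000 nM. In this assay compound 3 gives 34000 nM. The step between them is a 1.4-fold lower number from compound 1 to compound 3 (0.13 log units; within the scatter), so removing the bromo here changed nothing that can be told apart from measurement noise.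

Compound 2 `Cc1ccc(-c2nn(-c3ccccc3)cc2CNc2ccc(Br)cc2)cc1` is built on a core whose difference from the core of compound 1 is not broken down here. In this assay compound 2 reaches only a limit of the assay, > 100000 nM. This value is the limit of > 100000 nM in this assay, at which 1 of the 3 values shown sits.

Compound 4 `Cc1ccc(-c2nn(-c3ccccc3)cc2CNc2ccccc2)cc1` arises from compound 2 through (hydrogen in place of bromo on an aromatic carbon), the same change that leads from compound 1 to compound 3, at the same kind of place. Because the measured step of a 1.4-fold lower number from compound 1 to compound 3 (0.13 log units; within the scatter) stayed within the scatter, the expectation is that compound 4 will tolerate about as much as compound 2 does. For compound 4 the expected value in this assay is 120000 nM, estimated to fall between 50000 nM and 300000 nM. The step that this estimate means, a step that the limit leaves unreadable from compound 2 to compound 4, is expected to be small, and a limit rather than a number is expected to be the likely outcome once more.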

Compound 4, half-maximal cytotoxic concentration: > 100000 nM
Compound 4: only a limit was reported (the forecaster's own chance of this, stated with the estimate: 65%); the middle value lies beyond the limit too.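

In this assay, going by these compounds alone, compound 2 and compound 4 both stop at a limit of the assay rather than a number, so no step between them can be read: the limit of > 100000 nM in this assay, at which 2 of the 4 values shown sit. The compounds shown leave open how much of compound 2 or compound 4 the cells would tolerate, and whether hydrogen in place of bromo makes any difference in this pair.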